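A few compounds are considered here, and "the series" means these few. Any claim that something is new, unique, unknown or untested is made for them only; others in the source may bear on it.

Compound 1 `C=CC(=O)Nc1cc(Nc2ncc(Cl)c(Nc3ccccc3S(=O)(=O)C(C)C)n2)c(OC)cc1N1CCC(N2CCN(C)CC2)CC1` and compound 2 `C=CC(=O)Nc1cc(Nc2ncc(Cl)c(Nc3ccccc3S(=O)(=O)C(C)C)n2)c(OC)cc1N1CCN(C(C)C)CC1` share most of their structure, but the difference between their two cores is not broken down here. In a functional assay on NCI-H1975 cells (Homo sapiens) for inhibition, read by CellTiter-Glo, with a stated time of 72 h (a lower number here means a stronger inhibitor of growth, a higher number a weaker inhibitor of growth), compound 1 gives 23 nM. In this assay, among the compounds with values here, compound 2 gives 25 nM, a number within the scatter of the one for compound 1, so the two cannot be separated by this assay. Compound 3 `C=CC(=O)Nc1cc(Nc2ncc(Cl)c(Nc3ccccc3C#N)n2)c(OC)cc1N1CCN(C(C)C)CC1` differs from compound 2 in a single place: cyano in place of isopropylsulfonyl on an aromatic carbon This change produced a 17-fold higher number from compound 2 to compound 3 (1.24 log units; beyond the scatter), and in this assay compound 3 gives 430 nM.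

Compound 4 `C=CC(=O)Nc1cc(Nc2ncc(Cl)c(Nc3ccccc3C#N)n2)c(OC)cc1N1CCC(N2CCN(C)CC2)CC1` has not yet been measured. It stands to compound 1 as compound 3 stands to compound 2: cyano in place of isopropylsulfonyl on an aromatic carbon The place of the change is described in the same words for both pairs, so it is the same change, carried out on the core of compound 1 rather than on the core of compound 2. Within the data shown here, only one measured example of this change exists, so any expectation rests on that single step and on the observation that compound 1 and compound 2 start from numbers within the scatter of each other.

The step expected for compound 4 is a 17-fold higher number from compound 1 to compound 4 (1.24 log units; beyond the scatter), about the size of the earlier one. In this assay compound 4 is therefore estimated at 400 nM, with a range from 150 nM to 1000 nM.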

Compound 4, concentration for 50% growth inhibition: 200 nM
The estimate for compound 4 lay 2.0-fold (0.30 log units) above the measured number, and the stated range covers the measured number.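

Carried onto a second core, cyano in place of isopropylsulfonyl again weakened growth inhibition in this assay, with an 8.7-fold higher number from compound 1 to compound 4 (0.94 log units; beyond the scatter). Both steps run in the same direction and lie beyond the scatter, and the gap between them gives no sign that the size of the step depends on which of these two cores carries it: the same change on two cores in this assay, a 17-fold higher number (1.24 log units; beyond the scatter) from compound 2 to compound 3 and an 8.7-fold higher number (0.94 log units; beyond the scatter) from compound 1 to compound 4, 2.0-fold (0.30 log units) apart, within the scatter of two such steps. This shows that the loss seen on one core was not peculiar to it and that, on these two cores, the earlier step was a usable guide to the later one, but with one pair per core it does not show that the change would behave alike on any other core in the series, and it says nothing about why the change lowers activity in these cells.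

The compounds shown leave open whether methylsulfonyl, a primary carboxamide or a fluorine at the same aromatic carbon would give a number closer to that of isopropylsulfonyl or to that of cyano. They also leave open whether the step would hold on a core ending in a morpholine rather than in the amine groups of compound 1 and compound 2.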